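Methyl for Chloro on the Pendant Phenyl

A few compounds are considered here, and "the series" means these few. Any claim that something is new, unique, unknown or untested is made for them only; others in the source may bear on it.

Compound 1 `Cc1cccc(-c2noc(C3CC(=O)N(c4ccc(C)c(Cl)c4)C3)n2)c1` gives 240 nM in an in vitro functional assay on HEK293-A cells for positive allosteric modulation of metabotropic glutamate receptor 5 (Homo sapiens), read by FLIPR and calcium flux; on this read-out higher numbers stand for an effect only at larger amounts of compound and lower numbers for an effect already at smaller amounts.
Compound 2 `O=C1CC(c2nc(-c3cccc(Cl)c3)no2)CN1c1ccc(Cl)c(Cl)c1` gives 460 nM in this assay.

Of these two numbers, compound 2 and compound 1 lie within the scatter of repeated measurement of each other, so no difference between them can be claimed. Compound 3 `Cc1cccc(-c2noc(C3CC(=O)N(c4ccc(Cl)c(Cl)c4)C3)n2)c1` is reached from compound 2 by methyl in place of chloro on an aromatic carbon. Going by the values given here, no measured pair shows this change on its own, so its size is not known from the data. In this assay compound 3 is expected near 380 nM, with a range from 150 nM to 950 nM. This estimate means a step of a 1.2-fold lower number from compound 2 to compound 3 (0.08 log units; within the scatter) that is expected to stay within the scatter, in no clear direction.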

Compound 3, half-maximal effective concentration: 390 nM
Beside the measured number, compound 3's estimate is 1.0-fold (0.01 log units) below it; the measured number falls inside the stated range.
By their numbers in this assay, from the lowest: compounds 1, 3 and 2 (each within the scatter of the next).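

Methyl in place of chloro, 3-chlorophenyl to 3-methylphenyl, gives a 1.2-fold lower number from compound 2 to compound 3 (0.07 log units; within the scatter) in this assay and is now seen on its own at this position. The reverse swap at another aromatic carbon, chloro in place of methyl, gives a 1.6-fold higher number from compound 1 to compound 3 (0.21 log units; within the scatter) in the same read-out, so neither single change separates the compounds. Nothing measured here accounts for these results.

Going by these compounds, whether an amine, a carboxylic acid or a longer chain at this position would also stay within the scatter remains open.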